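This account rests on a few compounds, and the source may have more. Where it says the series, first, only, none or still open, it means among the compounds named here.

In a functional assay on HT-1080 cells (Homo sapiens) for inhibition, read by sulforhodamine B assay, with a stated time of 48 h (a higher number here means a weaker inhibitor, a lower number a stronger inhibitor), compound 1 `CCNC(=O)Nc1ccc(/C=C\c2cc(OC)c(OC)c(OC)c2)cc1` gives 29000 nM. Going by the values given here, this is the only exact number available so far, so there is no series against which to rank compound 1. Compound 2 `Cc1cc(C)cc(/C=C/c2ccc(N3CCNC3=O)cc2)c1` gives > 20000 nM, which is a limit of the assay and not a number.

Compound 3 `COc1cc(/C=C\c2ccc(N3CCNC3=O)cc2)cc(OC)c1OC` has not yet been measured. It keeps the rest of compound 1 unchanged but has 2-oxoimidazolidin-1-yl in place of (ethylcarbamoyl)amino on an aromatic carbon, para to a large group: 2-oxoimidazolidin-1-yl in place of (ethylcarbamoyl)amino on an aromatic carbon. The group that leaves has no ring, whereas the group that enters has one five-membered non-aromatic ring.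

Among the compounds with values here, no measured step shows what this exchange does in this assay. The expectation is therefore no step beyond the usual scatter of repeated measurements, in either direction, with compound 1 at 29000 nM as the only anchor. The expected change is a 1.5-fold lower number from compound 1 to compound 3 (0.16 log units; within the scatter). Compound 3 is estimated at 20000 nM, with an expected range from 2000 nM to 60000 nM. The range is wide, as a single exact number is a thin basis for an estimate.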

Compound 3, half-maximal inhibitory concentration: 2.3 nM
Estimate against measurement, compound 3: 8700-fold (3.94 log units) above; measured number outside the range, below it.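

In this assay, the large step comes from one exchange on the aromatic carbon para to a large group: a 13000-fold lower number from compound 1 to compound 3 (4.10 log units; beyond the scatter), with (ethylcarbamoyl)amino replaced by 2-oxoimidazolidin-1-yl. The two groups have the same heavy atoms, and they differ in that the entering group ties them into a five-membered non-aromatic ring and has 1 hydrogen-bond donor where the leaving group has 2, so this position responds very strongly to a change that leaves the atoms themselves the same. Compound 2 gives a limit of the assay and not a number, a reminder that the weak end of the scale is close to where exact readings stop, so the starting point of this step lies near that end: the limit of > 20000 nM in this assay, at which 1 of the 3 values shown sits.

Compound 2 also carries the 2-oxoimidazolidin-1-yl group but differs from compound 3 in more than one place, so it cannot show how much this group contributes on other cores. Going by these compounds, whether the gain follows from the ring itself or from the lost hydrogen-bond donor stays open, and a methyl group on the ring's remaining nitrogen, or a six-membered ring in its place, would bear on that question.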